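The source may hold more compounds than are shown below. What is called first, only, known or untested is meant among the compounds shown, and "the series" means these compounds.

Three measured compounds share one core and differ only at the outer ring groups. Compound 1 `Cc1ccc(-c2csc(NC(=O)COc3ccccc3C)n2)cc1` gives 53500 nM in a functional assay on MCF7 cells (Homo sapiens) for cytotoxicity, read by MTT assay, with a stated time of 48 h; on this read-out lower numbers stand for stronger inhibition and higher numbers for weaker inhibition. Compound 2 `Cc1ccc(-c2csc(NC(=O)COc3ccccc3C(C)C)n2)cc1` gives 49200 nM, and compound 3 `Cc1ccccc1OCC(=O)Nc1nc(-c2ccc(Cl)cc2)cs1` gives 62200 nM. Compound 1 thus sits second highest of the three numbers, but the whole spread is small: the step of a 1.1-fold lower number from compound 1 to compound 2 (0.04 log units; within the scatter) and the step of a 1.2-fold higher number from compound 1 to compound 3 (0.07 log units; within the scatter) both fall within the scatter, so the three compounds cannot be ordered with confidence.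

Compound 4 `Cc1ccc(OCC(=O)Nc2nc(-c3ccc(C)cc3)cs2)cc1` has the same atoms as compound 1, joined differently: 4-methylphenyl in place of 2-methylphenyl on an oxygen on a saturated carbon. Neither measured step is of quite this kind, since each of them swaps one group for another on an aromatic carbon rather than rearranging the methyl on the phenoxy ring, but both show that small edits to the outer groups leave this assay almost unchanged. Compound 4 is therefore expected to give 55000 nM, with a likely range from 25000 nM to 120000 nM, a step of a 1.0-fold higher number from compound 1 to compound 4 (0.01 log units; within the scatter) that is estimated to stay within the scatter.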

Compound 4, half-maximal inhibitory concentration: 41300 nM
For compound 4 the middle estimate is 1.3-fold (0.12 log units) above the measured one; low and high end bracket the measured number.
By their numbers in this assay, from the lowest: compounds 4, 2, 1 and 3 (each within the scatter of the next).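

Moving the methyl, so that 4-methylphenyl stands in place of 2-methylphenyl on the oxygen, alters only how the same atoms are joined, unlike the earlier swaps of one group for another. In this assay, this rearrangement gives a 1.3-fold lower number from compound 1 to compound 4 (0.11 log units; within the scatter), so compound 1 and compound 4 cannot be told apart, and for this pair the place of the methyl on that ring has no effect that can be detected in this assay. Nothing available explains this result or shows how these compounds act on the cells.

Going by these compounds, it remains open whether an amine or a carboxylic acid on this ring would give a step beyond the scatter. The same question applies to a longer chain in place of the methyl.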